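The source may report more compounds than this note shows. Statements on the series, on what has been measured and on what is new or still open speak of the compounds shown alone.

Working notes on the series.

Compound 3 `COc1cccc(CNCCCNc2ccnc3cc(Cc4ccc(F)cc4Cl)ccc23)c1O` gives the lowest of the three solubility numbers in hand: in a physicochemical assay for solubility, with a stated time of 18 h, at pH 7.4 (on this read-out lower numbers stand for lower solubility and higher numbers for higher solubility), compound 3 gives 4200 nM. Compound 1 `COc1cccc(CNCCCNc2ccnc3cc(Oc4ccccc4)ccc23)c1O` gives 14500 nM in this assay, and compound 2 `COc1ccc(F)cc1CNCCCNc1ccnc2cc(-c3cccc4ccccc34)ccc12` gives 32000 nM in this assay. Among the measured compounds shown here, the one single-point step in hand, a 3.5-fold lower number from compound 1 to compound 3 (0.54 log units; beyond the scatter), runs in the direction of lower solubility.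

Compound 4 `COc1cccc(CNCCCNc2ccnc3cc(-c4cccc5ccccc45)ccc23)c1O` is the unmeasured member. Relative to compound 3 the change is naphthalen-1-yl in place of 2-chloro-4-fluorobenzyl on an aromatic carbon. For the measured compounds named here, no measured step covers this replacement directly; the only compound bearing a naphthalen-1-yl group, compound 2, differs from compound 4 in a further place as well, so its value serves only as a loose pointer. Taking the number of compound 3 as the starting point and the higher number of compound 2 as a pointer, a small to modest rise in solubility is expected, a 1.9-fold higher number from compound 3 to compound 4 (0.28 log units; within the scatter), though a flat outcome within the scatter cannot be ruled out. The estimate for compound 4 in this assay is 8000 nM, with a range from 2500 nM to 25000 nM.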

Compound 4, solubility: 32000 nM
For compound 4 the middle estimate is 4.0-fold (0.60 log units) below the measured one; measured number above the stated range.
By their numbers in this assay, from the lowest: compound 3; then compound 1; then compounds 2 and 4 (each within the scatter of the next).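

At this aromatic carbon of the shared core, this assay separates all three groups: naphthalen-1-yl in place of 2-chloro-4-fluorobenzyl gives a 7.6-fold higher number from compound 3 to compound 4 (0.88 log units; beyond the scatter) and naphthalen-1-yl in place of phenoxy gives a 2.2-fold higher number from compound 1 to compound 4 (0.34 log units; beyond the scatter), which puts naphthalen-1-yl highest and 2-chloro-4-fluorobenzyl lowest of the three. Among the compounds shown here, with naphthalen-1-yl fixed, 2-hydroxy-3-methoxyphenyl in place of 5-fluoro-2-methoxyphenyl on the saturated chain carbon bound to an amine nitrogen gives no change at the digits printed from compound 2 to compound 4 (within the scatter), the first reading of that change. Nothing in hand gives a reason for these differences.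

On these data alone, whether that change at the chain end stays flat with phenoxy or 2-chloro-4-fluorobenzyl on the aromatic carbon remains open. So does the effect of a carboxylic acid or an amine at that aromatic carbon.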